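The source may report more compounds than this note shows. Statements on the series, on what has been measured and on what is new or still open speak of the compounds shown alone.

For the measured compounds named here, compound 2 `CN(C)CCn1cnnc1-c1cc(Oc2ccc(NC(=O)N/N=C/c3cccc(Cl)c3Cl)cc2F)ccn1` has the lowest of the two numbers so far: in a functional assay on MKN-45 cells (Homo sapiens) for cytotoxicity, read by MTT assay, with a stated time of 72 h (a higher number here means a weaker inhibitor, a lower number a stronger inhibitor), compound 2 gives 51 nM, while compound 1 `CN(C)CCn1cnnc1-c1cc(Oc2ccc(NC(=O)N/N=C/c3ccccc3O[N+](=O)[O-])cc2F)ccn1` gives 1020 nM. Going by the values given here, the one measured step, a 20-fold lower number from compound 1 to compound 2 (1.30 log units; beyond the scatter), shows that swapping the aryl group on this carbon can move the number a great deal. Compound 3 `CN(C)CCn1cnnc1-c1cc(Oc2ccc(NC(=O)N/N=C/c3cc(Br)c(O)c(Br)c3)cc2F)ccn1` makes another swap at the same place: 3,5-dibromo-4-hydroxyphenyl in place of 2,3-dichlorophenyl on a carbon with a double bond to nitrogen. Among the compounds with values here, with only that single step as a guide, a sizable move away from compound 2 is expected, most likely upward, and compound 3 is estimated at 200 nM, between 50 nM and 800 nM, a step of a 3.9-fold higher number from compound 2 to compound 3 (0.59 log units; beyond the scatter).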

Compound 3, half-maximal inhibitory concentration: 4320 nM
Beside the measured number, compound 3's estimate is 22-fold (1.33 log units) below it; the whole stated range lies below it.
By their numbers in this assay, from the lowest: compound 2; then compound 1; then compound 3.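

In this assay, a swap at this carbon can raise the number as sharply as it can lower it, with an 85-fold higher number from compound 2 to compound 3 (1.93 log units; beyond the scatter), even though compound 2 and compound 3 each carry two halogen atoms on the ring. The 3,5-dibromo-4-hydroxyphenyl group also ends above the 2-(nitrooxy)phenyl group, with a 4.2-fold higher number from compound 1 to compound 3 (0.63 log units; beyond the scatter). Nothing measured here explains these moves.

On these data alone, the bromine atoms and the hydroxyl enter together in compound 3, so the share of each stays open. A 4-hydroxyphenyl group or a 3,5-dibromophenyl group at this carbon would separate them.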